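The source may hold more compounds than are shown below. What is called first, only, known or untested is meant among the compounds shown, and "the series" means these compounds.

Measured so far:
- compound 1 `CCC(=O)N(c1ccc(Cl)c(Cl)c1)C1CCCC1O`: 9 mg/kg
- compound 2 `CCC(=O)N(c1ccc(Br)cc1)C1CCCC1N(C)C`: 3 mg/kg

In a functional assay on the whole organism for antagonist activity, with Mus musculus as the target (on this read-out higher numbers stand for an effect only at larger amounts of compound and lower numbers for an effect already at smaller amounts), compound 1 gives 9 mg/kg, the higher of the two numbers. Compound 2 gives 3 mg/kg, and this gap lies beyond the usual scatter. The two compounds differ in more than one place, so no measured single change is available as a guide.

Compound 3 `CCC(=O)N(c1ccc(Cl)c(Cl)c1)C1CCCC1N(C)Cc1ccccc1` follows from compound 1 through (benzyl(methyl)amino in place of hydroxy on a saturated ring carbon), with benzyl(methyl)amino in place of hydroxy on a saturated ring carbon. Compound 2, at 3 mg/kg, also carries an amino group on a saturated ring carbon, which gives weak support for a lower number in this assay. The expected change is small, a 1.5-fold lower number from compound 1 to compound 3 (0.18 log units; within the scatter), and the uncertainty is wide. The estimate for compound 3 is 6 mg/kg, with an expected range of 1.5 mg/kg to 30 mg/kg.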

Compound 3, dose for half-maximal effect: 40 mg/kg
Beside the measured number, compound 3's estimate is 6.7-fold (0.82 log units) below it; measured number outside the range, above it.
By their numbers in this assay, from the lowest: compound 2; then compound 1; then compound 3.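

Working notes on the series: the group on a saturated ring carbon of the five-membered ring is not neutral in this assay, since benzyl(methyl)amino in place of hydroxy gives a 4.4-fold higher number from compound 1 to compound 3 (0.65 log units; beyond the scatter) on the core of compound 1. The step runs towards an effect only at larger amounts of compound, so this exchange at this position brings no gain on this read-out. No measured data bear on the reason for the step.

The exchange brings in the amine nitrogen, the methyl and the benzyl ring at once, and the compounds shown do not separate their contributions. A methylamino group, a plain amine or a methoxy group on the same carbon of the core of compound 1 would bear on that question.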